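The source may report more compounds than this note shows. Statements on the series, on what has been measured and on what is new or still open speak of the compounds shown alone.

Of the compounds shown here, three of closely related build have been tested in a functional assay on HUVEC cells (Homo sapiens), read by BrdU incorporation, with a stated time of 72 h; on this read-out higher numbers stand for weaker inhibition and lower numbers for stronger inhibition. Compound 1 `Cc1ccc2nc(Cl)c(/C=C/C(=O)c3sccc3C)cc2c1` gives 127 nM in this assay, and compound 2 `Cc1ccc2nc(Cl)c(/C=C/C(=O)c3sccc3Cl)cc2c1` gives 37.5 nM. These two differ in only one spot, where the change methyl in place of chloro on an aromatic carbon is made, and that change produced a 3.4-fold higher number from compound 2 to compound 1 (0.53 log units; beyond the scatter). Compound 3 `Cc1cccc2cc(/C=C/C(=O)c3ccc(Cl)s3)c(Cl)nc12` shows 116 nM in this assay; it shares its atoms with compound 2, but the difference between the two cores is not broken down here. Its value sits close to that of compound 1, and the gap between them stays within the usual scatter.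

Compound 4 `Cc1ccc(C(=O)/C=C/c2cc3cccc(C)c3nc2Cl)s1` has not yet been measured in this assay. For the measured compounds named here, it is built from compound 3 by the change (methyl in place of chloro on an aromatic carbon), which is the same kind of change as the one from compound 2 to compound 1, but not the same: in compound 1 the methyl sits next to the ring atom that bears a large group and two ring bonds from the ring sulfur, while in compound 4 it sits next to the ring sulfur and two ring bonds from the ring atom that bears a large group. Because the earlier instance gave a 3.4-fold higher number from compound 2 to compound 1 (0.53 log units; beyond the scatter), a weakening of similar kind is expected here, though the different place leaves room for it to be smaller, so the estimated step is a 2.6-fold higher number from compound 3 to compound 4 (0.41 log units; beyond the scatter). Compound 4 is therefore expected to give about 300 nM in this assay, most likely between 120 nM and 800 nM.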

Compound 4, half-maximal inhibitory concentration: 145 nM
The estimate for compound 4 lay 2.1-fold (0.32 log units) above the measured number, and the stated range covers the measured number.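

In this assay, replacing 5-chlorothiophen-2-yl with 5-methylthiophen-2-yl gives a 1.3-fold higher number from compound 3 to compound 4 (0.10 log units; within the scatter), a step too small to tell apart from the ordinary variation between repeated measurements. Comparing this swap with the earlier one shows that, in this series, exchanging chloro for methyl does not have a single size that can be carried unchanged from one core, meaning the rest of the molecule, to another: the same change on two cores in this assay, a 3.4-fold higher number (0.53 log units; beyond the scatter) from compound 2 to compound 1 and a 1.3-fold higher number (0.10 log units; within the scatter) from compound 3 to compound 4, 2.7-fold (0.43 log units) apart, beyond the scatter of two such steps

This does not show what sets the size of the step, since the two pairs differ both in the core and in where the swap sits on the five-membered aromatic ring, and two pairs cannot separate those differences or give a rule for other cores.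

Still open, on these data alone, is whether the large step depends on the place on the ring or on the core, a question that would need the same swap at each place on each core. Also open is how other groups at the carbon in compound 4 would compare, such as a methoxy group, an amine or a carboxylic acid, as the compounds shown carry only chloro or methyl on this ring.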